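Aryl Swap on the Ether Carbon: Expected Cytotoxicity of Compound 3

The source may report more compounds than this note shows. Statements on the series, on what has been measured and on what is new or still open speak of the compounds shown alone.

Compound 1 `N#Cc1ccc(Nc2nccc(OCc3cccc(Cl)c3)n2)cc1`: 153000 nM
Compound 2 `N#Cc1ccc(Nc2nccc(OCc3ccccc3F)n2)cc1`: 151000 nM

In an ADME assay on MT4 cells (Homo sapiens) for cytotoxicity, read by MTT assay, with a stated time of 5 days (on this read-out higher numbers stand for lower toxicity in this test and lower numbers for higher toxicity in this test), compound 2 gives 151000 nM, and compound 1 gives 153000 nM; the two numbers lie within the scatter of one another, as the step of a 1.0-fold lower number from compound 1 to compound 2 (0.01 log units; within the scatter) shows. Compound 3 `N#Cc1ccc(COc2ccnc(Nc3ccc(C#N)cc3)n2)cc1` differs from compound 2 by 4-cyanophenyl in place of 2-fluorophenyl on a saturated chain carbon bound to an oxygen on an aromatic ring. Among the compounds with values here, the only measured step touching this position is a 1.0-fold lower number from compound 1 to compound 2 (0.01 log units; within the scatter), which also exchanged the aryl group and stayed within the scatter. Compound 3 is therefore expected to show no step beyond the scatter, a 1.0-fold lower number from compound 2 to compound 3 (0.00 log units; within the scatter). The estimate for compound 3 is 150000 nM, ranging from 60000 nM to 300000 nM.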

Compound 3, half-maximal cytotoxic concentration: 209000 nM
Estimate against measurement, compound 3: 1.4-fold (0.14 log units) below, within the range that was stated.
By their numbers in this assay, from the lowest: compounds 2, 1 and 3 (each within the scatter of the next).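

In this assay, 4-cyanophenyl on the saturated chain carbon bound to an oxygen on an aromatic ring brings a triple bond and a hydrogen-bond acceptor that 2-fluorophenyl does not carry, yet both steps stay within the scatter (a 1.4-fold higher number from compound 2 to compound 3 (0.14 log units; within the scatter); a 1.4-fold higher number from compound 1 to compound 3 (0.14 log units; within the scatter)). The three aryl groups shown therefore cannot be told apart at this position on this read-out. No evidence is available that would explain this result. On these data alone, whether an amine, a carboxylic acid or a longer chain in place of the aryl group would give a step beyond the scatter remains open.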